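Working notes: adding chloro to compound 2

A few compounds are considered here, and "the series" means these few. Any claim that something is new, unique, unknown or untested is made for them only; others in the source may bear on it.

Measured so far in a functional assay on SF-268 cells (Homo sapiens) for inhibition, read by sulforhodamine B assay, with a stated time of 48 h (on this read-out higher numbers stand for weaker inhibition of growth and lower numbers for stronger inhibition of growth), for this series:
- compound 1 (`O=C(Nc1cccc(-n2cc(-c3ccncc3)c(-c3ccc(Cl)c(O)c3)n2)c1)Nc1cccc(C(F)(F)F)c1`): 1950 nM
- compound 2 (`COc1cc(-c2nn(-c3cccc(NC(=O)c4cccc(C(F)(F)F)c4)c3)cc2-c2ccncc2)ccc1Cl`): 2130 nM

Going by the values given here, compound 2 lies within the scatter of compound 1, the only other measured compound. Compound 3 (`COc1cc(-c2nn(-c3cccc(NC(=O)c4ccc(Cl)c(C(F)(F)F)c4)c3)cc2-c2ccncc2)ccc1Cl`) differs from compound 2 in one place: chloro in place of hydrogen on an aromatic carbon (chloro in place of hydrogen on an aromatic carbon, ortho to a trifluoromethyl group and para to a large group). Among the compounds with values here, no measured pair shows this change, so the expectation rests on the structural change alone: a small shift toward stronger inhibition of growth in this assay that may not clear the scatter. The expected move is a 1.4-fold lower number from compound 2 to compound 3 (0.15 log units; within the scatter) in this read-out. Compound 3 is estimated at 1500 nM with an expected range from 550 nM to 3500 nM in this read-out.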

Compound 3, concentration for 50% growth inhibition: 4860 nM
Compound 3: the middle estimate sits 3.2-fold (0.51 log units) below what was measured; measured number above the stated range.
By their numbers in this assay, from the lowest: compounds 1 and 2 (each within the scatter of the next); then compound 3.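

In this assay, going by these compounds alone, the change from 3-(trifluoromethyl)phenyl to 4-chloro-3-(trifluoromethyl)phenyl gives a 2.3-fold higher number from compound 2 to compound 3 (0.36 log units; beyond the scatter) and is the first single-place step. At this position, ortho to a trifluoromethyl group and para to a large group, chloro in place of hydrogen weakens inhibition of growth in this one pair. No measurement on these compounds accounts for the step.

From the compounds shown here alone, whether the loss is specific to chloro stays open, since a fluoro, methyl or amine group at this carbon would test that. Going by these compounds, whether the same step holds on the core of compound 1 also remains open.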